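The source may hold more compounds than are shown below. What is called first, only, known or untested is meant among the compounds shown, and "the series" means these compounds.

The study centres on compound 1 `NC(=O)c1c(NC(=O)c2ccccc2C(F)(F)F)sc2c1CCN(C(=S)Nc1ccccc1Cl)C2`, a thiourea-bearing member of a small series tested in a functional assay on HL-60 cells (Homo sapiens) for antiproliferative activity, with a stated time of 24 h; on this read-out higher numbers stand for weaker inhibition and lower numbers for stronger inhibition. In this assay compound 1 gives 17600 nM, the highest of the two numbers recorded so far. For the measured compounds named here, its only measured companion is compound 2 `Cc1ccc(C(=O)Nc2sc3c(c2C(N)=O)CCN(C(=O)Nc2ccccc2Cl)C3)cc1`, which carries a urea and a different aryl amide and shows 14600 nM in this assay; the two numbers lie within the scatter of one another, so nothing can be said about which of the two is the stronger inhibitor.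

The new compound is compound 3 `NC(=O)c1c(NC(=O)c2cccc([N+](=O)[O-])c2)sc2c1CCN(C(=S)Nc1ccccc1Cl)C2`. It keeps the thiourea and the shared core of compound 1 and differs only in the aryl amide: 3-nitrophenyl in place of 2-(trifluoromethyl)phenyl on a carbonyl carbon. Going by the values given here, no single-point step of this sort has been measured, so there is no precedent to lean on. Since both measured compounds sit close together in this assay, compound 3 is expected to stay in the same region, with the step of a 1.0-fold higher number from compound 1 to compound 3 (0.01 log units; within the scatter) not exceeding the scatter. Compound 3 is thus estimated at 18000 nM, within 6000 nM to 55000 nM.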

Compound 3, half-maximal inhibitory concentration: 7040 nM
The estimate for compound 3 lay 2.6-fold (0.41 log units) above the measured number; low and high end bracket the measured number.
By their numbers in this assay, from the lowest: compound 3; then compounds 2 and 1 (each within the scatter of the next).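

In this assay, for the compounds shown here, 3-nitrophenyl in place of 2-(trifluoromethyl)phenyl on a carbonyl carbon gives a 2.5-fold lower number from compound 1 to compound 3 (0.40 log units; beyond the scatter) as the first step measured at a single place. With the thiourea and the shared core held fixed, it shows that the aryl group on this amide can move the number beyond the scatter, though the step is modest. The two group names differ both in the substituent and in its number on the ring, so this one step cannot be assigned to either difference, and nothing measured here accounts for it.

The compounds shown leave open whether the nitro group or its ring position matters more, a question that 3-(trifluoromethyl)phenyl and 2-nitrophenyl amides would address. They also leave open how an amine or a carboxylic acid on this phenyl ring would read, and whether the same exchange would give a similar step with a urea in place of the thiourea.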